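Shortening the ether chain on a cinnamoyl triketone core

The compounds below may be only part of what the source reports. "The series", "measured", "known", "first", "only" and "open" are said of these compounds alone.

Measured so far:
compound 1, `CCCC1=C(OC)C(CCC)(CCC)C(=O)/C(=C(O)\C=C\c2ccc(I)cc2)C1=O`, 2.8 uM
compound 2, `CCCC1=C(OCCC(C)C)C(CCC)(CCC)C(=O)/C(=C(O)\C=C\c2ccccc2)C1=O`, 17 uM
compound 3, `CCCC1(CC=C(C)C)C(=O)C(C(=O)/C=C/c2ccccc2)=C(O)C(CCC)(CCC)C1=O`, 8.4 uM

All three were tested in a functional assay on PC-3 cells (Homo sapiens) for antiproliferative activity, read by sulforhodamine B assay, with a stated time of 3 days; a lower number here means that less compound is needed, a higher number that more compound is needed for the effect. Among them compound 2 has the highest number, so it needs the most material for the same effect on the cells. Compound 3 sits closest to it, while compound 1 lies furthest away, with a markedly lower number; both gaps are beyond the usual scatter of the measurement. Compound 1 also carries an iodine on its outer ring and a much shorter ether, and compound 3 has its side chains arranged differently, so these comparisons are not single, clean steps.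

The untested compound 4, `CCCCOC1=C(CCC)C(=O)/C(=C(O)/C=C/c2ccccc2)C(=O)C1(CCC)CCC`, is reached from compound 2 by one small change: hydrogen in place of methyl on a saturated chain carbon bound to two saturated chain carbons. Put differently, the isopentyl ether becomes a butyl ether. Nothing measured here isolates the effect of trimming one carbon from this chain. For this assay only a modest change is expected, if any beyond the scatter, with the direction leaning slightly toward a lower number in view of compound 1 at 2.8 uM with its shorter ether. Compound 4 is therefore estimated at 12 uM, in a range from 4 uM to 35 uM. This expected step is a 1.4-fold lower number from compound 2 to compound 4 (0.15 log units; within the scatter).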

Compound 4, concentration for half-maximal effect: 9.6 uM
The estimate for compound 4 lay 1.3-fold (0.10 log units) above the measured number, and the stated range covers the measured number.
By their numbers in this assay, from the lowest: compound 1; then compounds 3, 4 and 2 (each within the scatter of the next, the first and the last beyond it).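

In this assay, within the data shown here, the change from isopentyl to butyl on the ether, with hydrogen in place of methyl on a saturated chain carbon bound to two saturated chain carbons, is the first comparison here that differs in only one place, and it gives a 1.8-fold lower number from compound 2 to compound 4 (0.25 log units; within the scatter). The branching methyl can therefore go without the two compounds becoming distinguishable in this measurement, so this part of the ether chain accepts a small trim, at least on the unsubstituted outer ring that compound 2 and compound 4 share. Nothing available here explains this outcome, which remains an observation about the numbers alone.

Going by these compounds, a single step of one carbon says little about how far this ether chain can be altered, so it remains open whether a much longer chain, a benzyl group or a chain ending in an amine would shift the number beyond the scatter. On these data alone, it is also open whether the same trim would read alike with iodine on the outer ring, as in compound 1.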